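Cyclopropylmethoxy in place of difluoroethoxy on compound 1

The source may hold more compounds than are shown below. What is called first, only, known or untested is meant among the compounds shown, and "the series" means these compounds.

Of the compounds shown here, two have so far been measured in a functional assay on CHO cells for antagonist activity at sphingosine 1-phosphate receptor 2 (Homo sapiens), read by GTPgammaS binding; on this read-out lower numbers stand for stronger inhibition and higher numbers for weaker inhibition. Compound 1, `O=C(O)Cn1nc(Cc2nc3cc(Cl)c(OCC(F)F)cc3[nH]2)c2ccccc2c1=O`, gives 15 nM in this assay, the lower of the two numbers. Compound 2, `CCn1nc(CC(=O)Nc2ccc(OC(F)(F)F)c(Cl)c2)c2ccccc2c1=O`, gives 473 nM in this assay, a number that stands well beyond the scatter above that of compound 1. Among the measured compounds shown here, the two differ in more than one place, so no single step between them has been worked out, and their values can only be set side by side.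

Compound 3, `O=C(O)Cn1nc(Cc2nc3cc(Cl)c(OCC4CC4)cc3[nH]2)c2ccccc2c1=O`, has not yet been measured. It differs from compound 1 in one place: cyclopropyl in place of difluoromethyl on a saturated chain carbon bound to an oxygen on an aromatic ring. No measured step of this kind exists among the compounds shown, so the size of the change is a matter of expectation. One expects a 1.5-fold higher number from compound 1 to compound 3 (0.17 log units; within the scatter) in this assay, that is, either no change beyond the scatter or a modestly higher number. Compound 3 is therefore estimated at 22 nM in this assay, within a range from 7 nM to 70 nM.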

Compound 3, half-maximal inhibitory concentration: 25 nM
For compound 3 the middle estimate is 1.1-fold (0.06 log units) below the measured one; low and high end bracket the measured number.
By their numbers in this assay, from the lowest: compounds 1 and 3 (each within the scatter of the next); then compound 2.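

In this assay, among the compounds shown here, cyclopropyl in place of difluoromethyl gives a 1.7-fold higher number from compound 1 to compound 3 (0.22 log units; within the scatter), the first step that can be read at a single place, and it shows that this saturated chain carbon bound to an oxygen on an aromatic ring accepts either group without a change beyond the scatter. For this pair, the fluorine atoms of the 2,2-difluoroethoxy group are therefore not needed to keep the number within the scatter of compound 1, since the all-carbon cyclopropylmethoxy group, with the same count of heavy atoms and a three-membered ring, serves equally well on this read-out. No measured property of these compounds bears on why the two groups read alike.

The compounds shown leave open how much more this place will accept, as only two groups of equal heavy-atom count have been compared there, so a longer chain such as n-butyl or a chain ending in an amine could read quite differently. They also leave open whether a larger ring, such as cyclohexyl, would stay within the scatter of compound 1 in this assay.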